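Swapping 3-fluorophenyl for 4-bromophenyl

The compounds below may be only part of what the source reports. "The series", "measured", "known", "first", "only" and "open" are said of these compounds alone.

Compound 1 `COc1cccc(-c2nc(N)c(Oc3ccccc3OC)c(Cl)n2)c1`: 23600 nM
Compound 2 `COc1ccccc1Oc1c(N)nc(-c2cccc(F)c2)nc1Cl`: 21700 nM

In a functional assay on B16 cells (Mus musculus) for cytotoxicity, read by CCK-8 assay, with a stated time of 24 h (a lower number here means a stronger inhibitor, a higher number a weaker inhibitor), compound 2 gives 21700 nM and stands level with compound 1 at 23600 nM. Within the data shown here, the only measured step, a 1.1-fold lower number from compound 1 to compound 2 (0.04 log units; within the scatter), is fluoro in place of methoxy on an aromatic carbon, and it leaves the two values within the scatter of each other.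

Compound 3 `COc1ccccc1Oc1c(N)nc(-c2ccc(Br)cc2)nc1Cl` has yet to be measured. Its difference from compound 2 is 4-bromophenyl in place of 3-fluorophenyl on an aromatic carbon. This puts 4-bromophenyl in place of 3-fluorophenyl on an aromatic carbon, between two ring nitrogen atoms. Among the measured compounds shown here, the one measured step bears on this change only loosely: it also altered the substituent on this aromatic group, and its size was small. For the measured compounds named here, no measured compound carries a 4-bromophenyl group, so the data give only weak guidance. No shift beyond the scatter is therefore expected in this assay, and no direction is firmly favoured. The expected change is a 1.2-fold lower number from compound 2 to compound 3 (0.08 log units; within the scatter). Compound 3 is estimated at 18000 nM, with an expected range of 8000 nM to 40000 nM.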

Compound 3, half-maximal inhibitory concentration: 4440 nM
Compound 3: middle estimate off by 4.1-fold (0.61 log units), on the high side; the measured number lies below the stated range.
By their numbers in this assay, from the lowest: compound 3; then compounds 2 and 1 (each within the scatter of the next).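

The group between two ring nitrogen atoms proves able to move the number in this assay: exchanging 3-fluorophenyl for 4-bromophenyl gives a 4.9-fold lower number from compound 2 to compound 3 (0.69 log units; beyond the scatter) beyond anything seen earlier, where a 1.1-fold lower number from compound 1 to compound 2 (0.04 log units; within the scatter) had stayed within the scatter. Exchanging 3-methoxyphenyl for 4-bromophenyl gives a similar result, a 5.3-fold lower number from compound 1 to compound 3 (0.73 log units; beyond the scatter) in the same direction, so compound 3 stands apart from both earlier compounds, while the two groups that left in these steps had been level with each other. The shift arises although 3-fluorophenyl and 4-bromophenyl have the same heavy-atom count and neither has hydrogen-bond donors or acceptors, and no measurement available here explains it.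

Both steps change the substituent and its place on the aromatic ring together, so the compounds shown leave open whether the bromo group itself or its place accounts for the lower number. They also leave open how a chloro group, a nitrile or an amine would behave in that same place on the ring.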